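Swapping a phenol for a trimethoxyphenyl on a shared core

The compounds below may be only part of what the source reports. "The series", "measured", "known", "first", "only" and "open" are said of these compounds alone.

compound 1 `CC[C@H](C)C(N)c1cc(C(F)(F)F)ccc1N1CCN(C(=O)CCc2ccc(Cl)cc2Cl)CC1` — 75 nM
compound 2 `CC(C)C[C@H](N)c1cc(C(F)(F)F)ccc1N1CCN(C(=O)CCc2ccc(O)cc2)CC1` — > 10000 nM

In an assay on HEK293 cells for displacement of a labelled ligand from Melanocortin receptor 4 (Homo sapiens) (on this read-out lower numbers stand for stronger inhibition and higher numbers for weaker inhibition), compound 1 gives 75 nM. For compound 2 this assay reports only a limit, > 10000 nM, which is the limit of > 10000 nM in this assay, at which 1 of the 2 values shown sits. Going by the values given here, compound 1 and compound 2 differ in more than one place, so their values show only that one yields a number and the other does not. Compound 3 `COc1cc(OC)c(OC)cc1CCC(=O)N1CCN(c2ccc(C(F)(F)F)cc2[C@@H](N)CC(C)C)CC1` carries 2,4,5-trimethoxyphenyl in place of 4-hydroxyphenyl on a saturated chain carbon, two bonds along the chain from a carbonyl carbon. Among the compounds with values here, no measured step of this kind is available, so the expectation rests on the structures alone. The expected step in this assay is an at least 3.3-fold lower number from compound 2 to compound 3 (0.52 log units; beyond the scatter), a gain that may exceed the scatter. Compound 3 is expected to give 3000 nM, within 400 nM to 20000 nM.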

Compound 3, inhibition constant: 6100 nM
Estimate against measurement, compound 3: 2.0-fold (0.31 log units) below, within the range that was stated.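

Going by these compounds alone, the first pair here that differs in one place shows that changing the aryl group on a saturated chain carbon, two bonds along the chain from a carbonyl carbon, can yield a measurable value in this assay. The change to 2,4,5-trimethoxyphenyl gives an at least 1.6-fold lower number from compound 2 to compound 3 (0.21 log units; that floor lies within the scatter). Compound 2 stands only at a limit: the limit of > 10000 nM in this assay, at which 1 of the 3 values shown sits.

As far as these compounds go, it remains open how a plain phenyl or a 4-methoxyphenyl would read at this place. That leaves unsettled whether the loss of the hydroxyl or the presence of the methoxy groups matters.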